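Swapping Diacetylamino for a Cyclic Imide on a Shared Core

This account rests on a few compounds, and the source may have more. Where it says the series, first, only, none or still open, it means among the compounds named here.

Compound 2 `CC(=O)N(C(C)=O)C1=C(C#N)C(c2ccc(F)cc2)C2=C(CC(C)(C)CC2=O)N1c1ccc(S(N)(=O)=O)cc1` carries a diacetylamino group on a double-bonded ring carbon of the shared core. In a functional assay on MCF7 cells (Homo sapiens) for cytotoxicity, read by sulforhodamine B assay, with a stated time of 48 h (a lower number here means a stronger inhibitor, a higher number a weaker inhibitor), compound 2 gives 79700 nM. Of the three measured numbers this is nominally the highest, but each gap lies within the scatter: compound 1 `CC1(C)CC(=O)C2=C(C1)N(c1ccc(S(N)(=O)=O)cc1)C(N)=C(C#N)C2c1ccc(F)cc1`, with a free amino group at that carbon, gives 71800 nM, and compound 3 `CC1(C)CC(=O)C2=C(C1)N(c1ccc(S(N)(=O)=O)cc1)C(NC(=O)CCl)=C(C#N)C2c1ccc(F)cc1`, with a (chloromethyl)carbonyl on that amine nitrogen, gives 70800 nM. Compound 4 `CC1(C)CC(=O)C2=C(C1)N(c1ccc(S(N)(=O)=O)cc1)C(N1C(=O)CCC1=O)=C(C#N)C2c1ccc(F)cc1` has not been measured; it differs from compound 2 by 2,5-dioxopyrrolidin-1-yl in place of diacetylamino on a double-bonded ring carbon. The measured steps that bear on this change sit at the same carbon: a 1.1-fold higher number from compound 1 to compound 2 (0.05 log units; within the scatter) and a 1.1-fold lower number from compound 2 to compound 3 (0.05 log units; within the scatter). Both lie within the scatter, so three different groups at that position gave about the same number. For compound 4 a step of about a 1.1-fold lower number from compound 2 to compound 4 (0.03 log units; within the scatter) is therefore expected, which is none beyond the scatter. The estimate for compound 4 in this assay is 75000 nM, with an expected range from 40000 nM to 140000 nM.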

Compound 4, half-maximal inhibitory concentration: 94100 nM
Estimate against measurement, compound 4: 1.3-fold (0.10 log units) below; the measured number falls inside the stated range.
By their numbers in this assay, from the lowest: compounds 3, 1, 2 and 4 (each within the scatter of the next).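

Tying the diacetylamino atoms into the ring of 2,5-dioxopyrrolidin-1-yl leaves the counts of heavy atoms and hydrogen-bond acceptors unchanged, and in this assay this swap gives a 1.2-fold higher number from compound 2 to compound 4 (0.07 log units; within the scatter) as its step. The ring also stays within the scatter of the other two groups at this carbon, with a 1.3-fold higher number from compound 3 to compound 4 (0.12 log units; within the scatter) and a 1.3-fold higher number from compound 1 to compound 4 (0.12 log units; within the scatter) as its steps, so ring and open-chain groups read alike here, and all four compounds agree with no exception. Nothing measured here explains why this carbon tolerates these groups so evenly.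

Going by these compounds, whether any group at this carbon can move the number beyond the scatter remains open, for instance a carboxylic acid, a basic amine or a longer alkyl chain on the amide nitrogen. Also open, on these data alone, is whether changing the 4-fluorophenyl or 4-sulfamoylphenyl group would matter more than this position does.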